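Leukotriene receptor series: acetophenone ethers with chain-terminal tetrazoles

The source may report more compounds than this note shows. Statements on the series, on what has been measured and on what is new or still open speak of the compounds shown alone.

Measured compounds:
Compound 1, `CC(=O)c1cc(CO)c(OCCCCCCC#N)cc1O`: 40%
Compound 2, `CCc1cc(C(C)=O)c(O)cc1OCCCCCC(C)(C)c1nnnn1C`: 99%
Compound 3, `CCCc1cc(C(C)=O)c(O)cc1OCCCCCC(=O)O`: 73%

The three compounds share the acetophenone core and differ in the ring substituent and in the group at the end of the ether chain. In an assay on isolated protein for inhibition of leukotriene B4 receptor 1 (Homo sapiens), tested at 10 uM (a higher number here means more inhibition at the concentration tested (going by the name of the read-out), a lower number less inhibition), compound 2 gives 99% and stands highest of the three numbers; compound 3 sits beyond the scatter below it, and compound 1 lies furthest below it, also beyond the scatter. For the measured compounds named here, no step between these compounds differs in one place only, so no single change can be isolated from the measured set.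

Compound 4, `CCc1cc(C(C)=O)c(O)cc1OCCCCCCC(=O)Nc1nn[nH]n1`, is the next compound, not yet measured. It keeps the ethyl-substituted core of compound 2 and changes the chain end: ((2H-tetrazol-5-yl)carbamoyl)methyl in place of 1-methyl-1-(1-methyl-1H-tetrazol-5-yl)ethyl on a saturated chain carbon, five bonds along the chain from an oxygen on an aromatic ring. Among the measured compounds, the chain end bearing a carboxylic acid, as in compound 3, gave 73% in this assay, a number below that of compound 2; the hydroxymethyl-substituted, nitrile-ended compound 1 gave 40%. Given the starting level of compound 2, the expected step is downward, probably of moderate size and beyond the scatter, as a number 19 percentage points lower from compound 2 to compound 4 (beyond the scatter). Compound 4 is therefore estimated at 80%, with a range from 55% to 98%.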

Compound 4, a percentage reported as inhibition, at one concentration (the size of the read-out at that concentration, not a potency): 101%
The estimate for compound 4 lay 21 percentage points below the measured number, outside the stated range (above it).
By their numbers in this assay, from the lowest: compound 1; then compound 3; then compounds 2 and 4 (each within the scatter of the next).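

For the compounds shown here, at this position, on a saturated chain carbon, five bonds along the chain from an oxygen on an aromatic ring, the first single-place comparison is now available: in this assay, ((2H-tetrazol-5-yl)carbamoyl)methyl in place of 1-methyl-1-(1-methyl-1H-tetrazol-5-yl)ethyl gives a number 2 percentage points higher from compound 2 to compound 4 (within the scatter). With the ethyl-substituted core held constant, this read-out therefore does not separate two chain ends that differ in their atoms and in their hydrogen-bond donor count, 0 for the group leaving and 2 for the group entering, although both carry a five-membered aromatic ring with 4 hetero atoms. Nothing available explains why the two chain ends read alike.

Since this assay reports inhibition at one concentration and not a potency, any difference in potency between compound 2 and compound 4 remains unresolved. The compounds shown also leave open whether the same level of inhibition would hold with a methylsulfonamide or a primary amine at this position, or with a longer chain carrying the ((2H-tetrazol-5-yl)carbamoyl)methyl end.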